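The source may report more compounds than this note shows. Statements on the series, on what has been measured and on what is new or still open speak of the compounds shown alone.

Working notes on the series. Compound 1 `C[C@H]1O[C@@H](n2ccc(=O)[nH]c2=O)C=C(F)C1=O` and compound 2 `C[C@H]1O[C@@H](n2cc(F)c(=O)[nH]c2=O)C=C(F)C1=O` share one core. In a functional assay on FM3A cells (Mus musculus) for cytotoxicity (on this read-out lower numbers stand for stronger inhibition and higher numbers for weaker inhibition), compound 1 gives 16000 nM, and compound 2 gives 490 nM; the step of a 33-fold lower number from compound 1 to compound 2 (1.51 log units; beyond the scatter) leaves compound 2 with the lowest number of the two. Compound 3 `Cc1cn([C@H]2C=C(F)C(=O)[C@@H](C)O2)c(=O)[nH]c1=O` carries methyl in place of fluoro on an aromatic carbon. Among the compounds with values here, no measured step swaps fluoro for methyl; only the fluoro-for-hydrogen step from compound 1 to compound 2 bears on it, and it was large. Removing that fluoro is therefore expected to raise the number again, so compound 3 is expected at 6000 nM, between 1200 nM and 30000 nM, a step of a 12-fold higher number from compound 2 to compound 3 (1.09 log units; beyond the scatter).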

Compound 3, half-maximal inhibitory concentration: 10000 nM
Compound 3: the middle estimate sits 1.7-fold (0.22 log units) below what was measured, and the stated range covers the measured number.
By their numbers in this assay, from the lowest: compound 2; then compounds 3 and 1 (each within the scatter of the next).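

At this position, a substituent alone does not lower the number: in this assay methyl in place of fluoro gives a 20-fold higher number from compound 2 to compound 3 (1.31 log units; beyond the scatter) and methyl in place of hydrogen gives a 1.6-fold lower number from compound 1 to compound 3 (0.20 log units; within the scatter), so methyl does not reproduce the fluoro step. Among the three groups shown at this aromatic carbon, only fluoro separates from the others. No measurement on hand explains this difference. From the compounds shown here alone, whether a chloro group, a trifluoromethyl group or an amine here would behave like fluoro or like methyl remains open.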